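This account rests on a few compounds, and the source may have more. Where it says the series, first, only, none or still open, it means among the compounds named here.

Compound 1, `C#CCNC(=O)/C(C)=C(\C)c1ccc(OC)cc1`, gives 150 mg/kg in a toxicity assay on the whole organism (strain Icem-CET (SPF Caw)) for cytotoxicity, with Mus musculus as the target; on this read-out lower numbers stand for an effect already at smaller amounts and higher numbers for an effect only at larger amounts of compound.
Compound 2, `C#CCNC(=O)/C(C)=C(\C)c1ccc(C)cc1`, gives 150 mg/kg in this assay.
Compound 3, `C/C(C(=O)NC1CC1)=C(/C)c1ccc(C)cc1`, gives 150 mg/kg in this assay.

The three measured compounds sit level with one another in this assay. Two single changes link them. Compound 1 differs from compound 2 only by methoxy in place of methyl on an aromatic carbon, and in this assay this gives no change at the digits printed from compound 2 to compound 1 (within the scatter). Compound 3 differs from compound 2 only by cyclopropyl in place of propargyl on an amide-type nitrogen, and here too this assay shows no change at the digits printed from compound 2 to compound 3 (within the scatter). The second of these changes is also what sets the core of compound 3 apart from the core of compound 2.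

Compound 4, `COc1ccc(/C(C)=C(\C)C(=O)NC2CC2)cc1`, has not yet been measured in this assay. It differs from compound 3 by methoxy in place of methyl on an aromatic carbon. This is the same change that was made from compound 2 to compound 1: the group that leaves, the group that enters and the place are described in the same words for both pairs. Moving from compound 3 to compound 4 is therefore expected to look like that earlier step, which showed no change at the digits printed from compound 2 to compound 1 (within the scatter), so an expected step of no change at the digits printed from compound 3 to compound 4 (within the scatter) is reasonable, resting on compound 3 at 150 mg/kg as the starting point. For compound 4 the estimate in this assay is 150 mg/kg, expected to fall between 75 mg/kg and 300 mg/kg.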

Compound 4, dose for half-maximal effect: 250 mg/kg
Compound 4: the middle estimate sits 1.7-fold (0.22 log units) below what was measured; the measured number falls inside the stated range.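

In this assay, methoxy in place of methyl on an aromatic carbon gives a 1.7-fold higher number from compound 3 to compound 4 (0.22 log units; within the scatter), and set beside the same change on the other core it behaves alike: the same change on two cores in this assay, no change at the digits printed (within the scatter) from compound 2 to compound 1 and a 1.7-fold higher number (0.22 log units; within the scatter) from compound 3 to compound 4, 1.7-fold (0.22 log units) apart, within the scatter of two such steps. Cyclopropyl in place of propargyl on an amide-type nitrogen gives a 1.7-fold higher number from compound 1 to compound 4 (0.22 log units; within the scatter), and this change also carries over between cores: the same change on two cores in this assay, no change at the digits printed (within the scatter) from compound 2 to compound 3 and a 1.7-fold higher number (0.22 log units; within the scatter) from compound 1 to compound 4, 1.7-fold (0.22 log units) apart, within the scatter of two such steps. Within these four compounds, then, each change can be moved to the second core without a gap that stands out from the scatter, but this does not show that either change is without effect in general, since steps this small cannot separate a slight real shift from the noise of repeated measurements, and each change has been seen on only one pair of cores.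

The compounds shown leave open whether this agreement would hold for other groups, such as a chlorine atom or a carboxylic acid on the aromatic carbon, or a longer chain or an amine on the amide-type nitrogen. On these data alone, they also rest on a single whole-organism read-out, so how the four compounds compare on any other measure remains unknown.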